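A Methyl Added to Compound 2: What Is Expected

A few compounds are considered here, and "the series" means these few. Any claim that something is new, unique, unknown or untested is made for them only; others in the source may bear on it.

Of the compounds shown here, two have been measured so far. Compound 1, `Cc1nc(C)c(COC(=O)CCCC[C@@H]2CCSS2)nc1C`, gives 160% in a functional assay on ECV-304 cells (Homo sapiens), read by MTT assay, with stated times of 24 h and 12 h, tested at 50 uM; on this read-out lower numbers stand for a weaker effect and higher numbers for a stronger effect at the one concentration tested. Compound 2, `Cc1nc(C)c(COc2ccc3ccc(=O)oc3c2)nc1C`, gives 44.2% in this assay; this is the lower of the two numbers, and its gap to compound 1 lies beyond the usual scatter of the measurement.

Compound 3, `Cc1nc(C)c(COc2ccc3c(C)cc(=O)oc3c2)nc1C`, has not yet been measured. It differs from compound 2 in one place: methyl in place of hydrogen on an aromatic carbon. The new group sits on an aromatic carbon of a six-membered aromatic ring with one oxygen, part of a fused system of two rings, opposite the ring oxygen.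

Among the compounds with values here, no measured pair in this set carries such a change, and the direction it takes is unknown. The step of a number 3.8 percentage points higher from compound 2 to compound 3 (within the scatter) is expected to stay within the scatter, with no clear direction. Compound 3 is thus estimated to give 48% in this assay, with a range from 30% to 70%.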

Compound 3, a percentage reported as activity, at one concentration (the size of the read-out at that concentration, not a potency): 25.8%
Estimate against measurement, compound 3: 22.2 percentage points above; measured number outside the range, below it.
By their numbers in this assay, from the lowest: compound 3; then compound 2; then compound 1.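

In this assay, methyl in place of hydrogen on an aromatic carbon, opposite the ring oxygen, gives a number 18.4 percentage points lower from compound 2 to compound 3 (beyond the scatter) and so marks a weaker effect at the one concentration tested. Within the data shown here, this is the first step in the set that changes one place only, and it shows that this position is not silent: a single added carbon here is enough to move the read-out, and it moves it downward. Nothing available explains why the number falls.

A single methyl cannot show whether the fall continues with other groups on this same aromatic carbon, such as an ethyl, a methoxy or an amine. As far as these compounds go, it also remains open whether methyl on another carbon of this ring would give a step of similar direction and size.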